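A few compounds are considered here, and "the series" means these few. Any claim that something is new, unique, unknown or untested is made for them only; others in the source may bear on it.

Among the compounds with values here, compound 1 `O=C(O)CCc1ccc2[nH]c(-c3ccccc3F)cc2c1` is the one member of the series with a number in a functional assay on CHO cells for agonist activity at Free fatty acid receptor 1 (Homo sapiens), read by a luciferase reporter, with a stated time of 24 h; on this read-out lower numbers stand for an effect already at smaller amounts and higher numbers for an effect only at larger amounts of compound; there compound 1 gives 1210 nM. Compound 2 `COc1ccc(-c2cc3cc(CCC(=O)O)ccc3[nH]2)cc1` returns in this assay only a limit of the assay, > 25 nM. No comparison between the two measured compounds is therefore possible, as the limit of > 25 nM in this assay, at which 1 of the 2 values shown sits, records. Compound 3 `O=C(O)CCc1ccc2[nH]c(-c3ccccc3Cl)cc2c1` differs from compound 1 by chloro in place of fluoro on an aromatic carbon. Within the data shown here, no measured pair shows such an exchange, so the change is expected to stay within the scatter, leaning if at all toward an effect at smaller amounts, a 1.3-fold lower number from compound 1 to compound 3 (0.13 log units; within the scatter). Compound 3 is thus estimated at 900 nM, with a range from 400 nM to 2500 nM.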

Compound 3, half-maximal effective concentration: 54.6 nM
Compound 3: middle estimate off by 16-fold (1.22 log units), on the high side; the measured number lies below the stated range.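

Chloro in place of fluoro, on an aromatic carbon ortho to a large group, gives a 22-fold lower number from compound 1 to compound 3 (1.35 log units; beyond the scatter) in this assay, the first exchange in the series that can be read as a step. This position therefore responds strongly to a change of a single heavy atom, and the choice of halogen here is not neutral. Within the data shown here, nothing measured so far accounts for the size of this step.

Open, as far as these compounds go, is whether bromo, methyl or trifluoromethyl at this place would extend the step or reverse it. Also open, from the compounds shown here alone, is whether the step would hold with a tetrazole in place of the carboxylic acid.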